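The source may hold more compounds than are shown below. What is called first, only, known or untested is meant among the compounds shown, and "the series" means these compounds.

Values in a functional assay on A549 cells (Homo sapiens) for inhibition, read by MTT assay, with a stated time of 48 h; a lower number here means a stronger inhibitor, a higher number a weaker inhibitor:
- Compound 1 `COc1cccc(C(c2c[nH]c3ccc(Br)cc23)c2c[nH]c3ccc(Br)cc23)c1OC`: 100000 nM
- Compound 2 `COc1ccc(OC)c(C(c2c[nH]c3ccc(Br)cc23)c2c[nH]c3ccc(Br)cc23)c1`: 10000 nM
- Compound 3 `Clc1ccc(C(c2c[nH]c3ccc(Br)cc23)c2c[nH]c3ccc(Br)cc23)cc1`: 8500 nM

These three compounds share a core and differ only in the substituted phenyl on a saturated chain carbon. Compound 3, at 8500 nM, cannot be separated from compound 2, since a 1.2-fold lower number from compound 2 to compound 3 (0.07 log units; within the scatter) stays within the usual scatter. Both sit clearly under compound 1.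

Compound 4 `O=[N+]([O-])c1ccc(C(c2c[nH]c3ccc(Br)cc23)c2c[nH]c3ccc(Br)cc23)cc1` keeps everything in compound 3 except one group: nitro in place of chloro on an aromatic carbon.

Within the data shown here, no measured step makes this exact swap, so the evidence is indirect. The two large steps, a 10-fold lower number from compound 1 to compound 2 (1.00 log units; beyond the scatter) and a 12-fold lower number from compound 1 to compound 3 (1.07 log units; beyond the scatter), both leave the 2,3-dimethoxyphenyl compound. The step that replaces one phenyl group with a different one without involving compound 1, a 1.2-fold lower number from compound 2 to compound 3 (0.07 log units; within the scatter), is small. Among the measured compounds shown here, with only three compounds this is thin support, so no step beyond the scatter is expected in this assay, and no direction can be favoured with confidence.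

For compound 4 the expected value is 9000 nM, with an estimated range from 3000 nM to 35000 nM. This estimate means an expected 1.1-fold higher number from compound 3 to compound 4 (0.02 log units; within the scatter).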

Compound 4, half-maximal inhibitory concentration: 5500 nM
Beside the measured number, compound 4's estimate is 1.6-fold (0.21 log units) above it; measured number inside the range.
By their numbers in this assay, from the lowest: compounds 4, 3 and 2 (each within the scatter of the next); then compound 1.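

In this assay the place on the aromatic carbon para to a large group accepts nitro, with three heavy atoms and two hydrogen-bond acceptors, in place of chloro, a single heavy atom with no acceptors, and the two compounds cannot be told apart (a 1.5-fold lower number from compound 3 to compound 4 (0.19 log units; within the scatter)). Compound 4 also cannot be separated from the 2,5-dimethoxyphenyl compound (a 1.8-fold lower number from compound 2 to compound 4 (0.26 log units; within the scatter)), whereas the gap from the 2,3-dimethoxyphenyl compound is large (an 18-fold lower number from compound 1 to compound 4 (1.26 log units; beyond the scatter)), so compound 1 remains the only one of the four that stands apart. No measured property of these groups is available to explain this result.

From the compounds shown here alone, two groups at this place are too few to show how much the number depends on what sits there, so it remains open whether an amine, a carboxylic acid or a plain hydrogen in the same place would also stay within the scatter of compound 3 or would shift the number clearly. Going by these compounds, it is also open whether a group on the 4-position of this phenyl ring, such as a longer chain, could bring the number well below those of compounds 2, 3 and 4.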